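Swapping the aryl group on the oxazole core and liver stability

The source may hold more compounds than are shown below. What is called first, only, known or untested is meant among the compounds shown, and "the series" means these compounds.

This series shares a core, shown by the structure of compound 1 `Cc1oc(-c2ccccc2Cl)nc1CN1CCC(C(=O)NCCCN2C[C@H](C)C[C@H](C)C2)CC1`, and is followed in an ADME assay on microsomes from liver (Rattus norvegicus) for metabolic stability, read by LC-MS, using NADPH, at 37 degrees C; a lower number here means that the compound disappears faster, a higher number that the compound lasts longer. Compound 1 gives 0.25 h there. Compound 3 `Cc1cccc(Cl)c1-c1nc(CN2CCC(C(=O)NCCCN3CCC(C)(C)CC3)CC2)c(C)o1` gives 0.0733 h in this assay, a lower number than compound 1, and the gap between the two lies beyond the usual scatter, so compound 1 holds the highest of the two numbers that were actually read. Compound 2 `Cc1ccccc1-c1nc(CN2CCC(C(=O)NCCCN3CCC(C)CC3)CC2)c(C)o1` gives > 0.5 h in this assay; that is a limit of the assay and not a number, and it matches (the limit of > 0.5 h in this assay, at which 1 of the 3 values shown sits).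

The step to compound 4 `COc1cccc(Br)c1-c1nc(CN2CCC(C(=O)NCCCN3C[C@H](C)C[C@H](C)C3)CC2)c(C)o1` places 2-bromo-6-methoxyphenyl in place of 2-chlorophenyl on an aromatic carbon of the five-membered ring, next to the ring nitrogen and the ring oxygen (2-bromo-6-methoxyphenyl in place of 2-chlorophenyl on an aromatic carbon). Going by the values given here, no measured pair shows exactly this change, so the direction cannot be read from the data. For compound 4 the expected step in this assay is a 1.1-fold lower number from compound 1 to compound 4 (0.06 log units; within the scatter), a change that is expected to stay within the scatter. Compound 4 is therefore estimated at 0.22 h, with a range from 0.08 h to 0.5 h.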

Compound 4, half-life: 0.0583 h
Estimate against measurement, compound 4: 3.8-fold (0.58 log units) above, outside the stated range (below it).
By their numbers in this assay, from the lowest: compounds 4 and 3 (each within the scatter of the next); then compound 1. At a limit, above all of these: compound 2.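

With the rest of the structure unchanged, placing 2-bromo-6-methoxyphenyl in place of 2-chlorophenyl on this aromatic carbon of the shared core gives a 4.3-fold lower number from compound 1 to compound 4 (0.63 log units; beyond the scatter) in this assay. Going by these compounds alone, this pair differs in one place only, so it is the first direct sign that the aryl group at this position can change how long a compound lasts with liver microsomes, and here the compound disappears faster. The entering group differs from the leaving one in two ways, with bromine where the leaving group has chlorine and an added methoxy group, and a single step cannot divide its size between them.

A 2-bromophenyl or a 2-methoxyphenyl group at this position, with the rest of compound 1 kept, would be the comparison that separates those two parts of the change. The values shown give no measured property that accounts for this step.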